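Moving the fluorine around the chlorophenyl ring

The source may report more compounds than this note shows. Statements on the series, on what has been measured and on what is new or still open speak of the compounds shown alone.

Compound 1 `Clc1ccccc1-c1cc(-c2cnn(C3CCNCC3)c2)on1`: 120 nM
Compound 2 `Fc1cccc(Cl)c1-c1cc(-c2cnn(C3CCNCC3)c2)on1`: 48 nM
Compound 3 `Fc1ccc(-c2cc(-c3cnn(C4CCNCC4)c3)on2)c(Cl)c1`: 220 nM

Compound 3 gives the highest number of the three in an assay on isolated protein for positive allosteric modulation of Neuronal acetylcholine receptor; alpha4/beta2 (Homo sapiens); a lower number here means that less compound is needed, a higher number that more compound is needed for the effect. One step is a 1.8-fold higher number from compound 1 to compound 3 (0.26 log units; within the scatter), which is within the scatter, while the other is a 4.6-fold higher number from compound 2 to compound 3 (0.66 log units; beyond the scatter), beyond it. Compound 4 `Fc1cccc(-c2cc(-c3cnn(C4CCNCC4)c3)on2)c1Cl` keeps every atom of compound 3 but joins them differently: 2-chloro-3-fluorophenyl in place of 2-chloro-4-fluorophenyl on an aromatic carbon. Among the measured compounds shown here, the only steps that bear on this change shift a single fluorine on the same ring. Adding fluorine gave a 2.5-fold lower number from compound 1 to compound 2 (0.40 log units; beyond the scatter) in one place and a 1.8-fold higher number from compound 1 to compound 3 (0.26 log units; within the scatter) in another. For the measured compounds named here, no measured step puts fluorine where compound 4 carries it, so a modest movement in either direction is expected. The expected step is a 1.5-fold lower number from compound 3 to compound 4 (0.17 log units; within the scatter), giving compound 4 an estimated 150 nM, between 50 nM and 450 nM.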

Compound 4, half-maximal effective concentration: 230 nM
For compound 4 the middle estimate is 1.5-fold (0.19 log units) below the measured one, and the stated range covers the measured number.
By their numbers in this assay, from the lowest: compound 2; then compounds 1, 3 and 4 (each within the scatter of the next).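

The move to 2-chloro-3-fluorophenyl brings a 1.0-fold higher number from compound 3 to compound 4 (0.02 log units; within the scatter) in this assay and so cannot be told apart from 2-chloro-4-fluorophenyl. Adding this fluorine gives a 1.9-fold higher number from compound 1 to compound 4 (0.28 log units; within the scatter) and thus no readable gain over the compound without fluorine, whereas a 4.8-fold higher number from compound 2 to compound 4 (0.68 log units; beyond the scatter) leaves 2-chloro-6-fluorophenyl as the only placement shown that stands apart from the others. No measured evidence is available to explain this difference between the placements.

As far as these compounds go, how a methoxy group or a nitrile would behave on this ring remains open. So does the effect of bromine in place of the chlorine.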